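The source may report more compounds than this note shows. Statements on the series, on what has been measured and on what is new or still open speak of the compounds shown alone.

The measured compounds, each in a functional assay on PC-3 cells (Homo sapiens) for inhibition; a lower number here means a stronger inhibitor, a higher number a weaker inhibitor:
compound 1, `COc1cc2nc(N3CCN(S(=O)(=O)c4ccc(I)cc4)CC3)nc(N)c2cc1OC`, gives 15000 nM
compound 2, `COc1ccc(S(=O)(=O)N2CCN(c3nc(N)c4cc(OC)c(OC)cc4n3)CC2)cc1`, gives 39000 nM
compound 3, `COc1cc2nc(N3CCN(S(=O)(=O)c4ccc(S(C)(=O)=O)cc4)CC3)nc(N)c2cc1OC`, gives 17000 nM

All three share the same core and differ only in the group on the aromatic ring of the sulfonyl part. Compound 3 stands second highest of the three numbers, which means it is neither the strongest nor the weakest inhibitor shown. Its gap to compound 1 is small: a 1.1-fold higher number from compound 1 to compound 3 (0.05 log units; within the scatter). Its gap to compound 2 is larger: a 2.3-fold lower number from compound 2 to compound 3 (0.36 log units; beyond the scatter). The remaining measured step is a 2.6-fold higher number from compound 1 to compound 2 (0.41 log units; beyond the scatter).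

Compound 4, `COc1cc2nc(N3CCN(S(=O)(=O)c4ccc(-c5ccc(S(C)(=O)=O)cc5)cc4)CC3)nc(N)c2cc1OC`, differs from compound 3 in one place: 4-(methylsulfonyl)phenyl in place of methylsulfonyl on an aromatic carbon. Going by the values given here, none of the measured steps adds a whole aromatic ring; each of them swaps one small group for another at the same place, and the largest of them stayed modest. So no measured step bears directly on this change, and the only guide is that all three numbers sit within a narrow, weak band. The expected step is a 1.1-fold lower number from compound 3 to compound 4 (0.05 log units; within the scatter), with wide uncertainty. Compound 4 is estimated at 15000 nM, in the range 4000 nM to 60000 nM.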

Compound 4, half-maximal inhibitory concentration: 7200 nM
Compound 4: the middle estimate sits 2.1-fold (0.32 log units) above what was measured, within the range that was stated.
By their numbers in this assay, from the lowest: compound 4; then compounds 1 and 3 (each within the scatter of the next); then compound 2.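

In this assay, this position accepts a much larger group without any loss of inhibition: placing 4-(methylsulfonyl)phenyl where methylsulfonyl stood gives a 2.4-fold lower number from compound 3 to compound 4 (0.37 log units; beyond the scatter), and the same group compares well with the other two small groups, with a 2.1-fold lower number from compound 1 to compound 4 (0.32 log units; beyond the scatter) and a 5.4-fold lower number from compound 2 to compound 4 (0.73 log units; beyond the scatter). The added aromatic ring therefore moves the number out of the narrow band held by the small groups and makes compound 4 the strongest inhibitor of the four, although each of these steps is only modest. Nothing available explains why the larger group gives a lower number.

Going by these compounds, it remains open whether the added ring alone accounts for the shift or whether the methylsulfonyl at its far end is also needed, a question that a plain phenyl group at the same place would help to answer. On these data alone, it is also open how this position would respond to a phenyl ring carrying an amine or a carboxylic acid instead, or to a longer alkyl chain with no ring at all.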